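Chloro for Fluoro on Two Cores: an Expected Small Step

This account rests on a few compounds, and the source may have more. Where it says the series, first, only, none or still open, it means among the compounds named here.

Three compounds have been measured in a functional assay on A549 cells (Homo sapiens) for antiproliferative activity, read by MTT assay, with a stated time of 48 h; a higher number here means a weaker inhibitor, a lower number a stronger inhibitor:

Compound 1, `Fc1ccc2[nH]c(-c3cn(-c4ccccc4)nc3-c3ccccc3)nc2c1`, gives 1720 nM.
Compound 2, `Clc1ccc2[nH]c(-c3cn(-c4ccccc4)nc3-c3ccccc3)nc2c1`, gives 2370 nM.
Compound 3, `Fc1ccc(-c2nn(-c3ccccc3)cc2-c2nc3ccccc3[nH]2)cc1`, gives 1510 nM.

Compounds 1 and 2 share one core, compound 3 carries another, and the difference between the two cores is not broken down here. From compound 1 to compound 2 the change is chloro in place of fluoro on an aromatic carbon. Its step in this assay is a 1.4-fold higher number from compound 1 to compound 2 (0.14 log units; within the scatter).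

Compound 4, `Clc1ccc(-c2nn(-c3ccccc3)cc2-c2nc3ccccc3[nH]2)cc1`, is not yet measured. It differs from compound 3 by chloro in place of fluoro on an aromatic carbon. The surroundings are not identical: in compounds 1 and 2 the carbon belongs to a six-membered aromatic ring of carbon only that is part of a fused or bridged system of two rings, meta to a fused ring and para to a fused ring, whereas in compounds 3 and 4 it lies in a six-membered aromatic ring of carbon only, para to a large group. It is therefore the same kind of change, not the same change.

The values of compounds 1 and 3 lie within the scatter of each other. Because a 1.4-fold higher number from compound 1 to compound 2 (0.14 log units; within the scatter) stayed within the scatter, a similarly small step is expected from compound 3 to compound 4, namely a 1.3-fold higher number from compound 3 to compound 4 (0.12 log units; within the scatter). Compound 4 is thus estimated at 2000 nM, with a likely range from 1000 nM to 4200 nM.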

Compound 4, half-maximal inhibitory concentration: 5960 nM
Estimate against measurement, compound 4: 3.0-fold (0.47 log units) below; the measured number lies above the stated range.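

In this assay, chloro in place of fluoro on an aromatic carbon gives a 3.9-fold higher number from compound 3 to compound 4 (0.60 log units; beyond the scatter), so the small step seen on the core of compound 1 did not carry over to the core of compound 3. In this series, the size of the change therefore cannot be taken from one core to the other, as the two steps show: the same change on two cores in this assay, a 1.4-fold higher number (0.14 log units; within the scatter) from compound 1 to compound 2 and a 3.9-fold higher number (0.60 log units; beyond the scatter) from compound 3 to compound 4, 2.9-fold (0.46 log units) apart, beyond the scatter of two such steps This does not show why the steps differ, since the two pairs differ in both the core and the surroundings of the changed carbon, and a single pair on each core cannot separate these or support a rule beyond these four compounds.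

As far as these compounds go, it remains open whether the larger step belongs to chloro in particular or would also appear with a methyl, a methoxy group or an amine in that same place on the phenyl ring. Also open, from the compounds shown here alone, is whether a second pair on each core would repeat the gap between the two steps.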